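This account rests on a few compounds, and the source may have more. Where it says the series, first, only, none or still open, it means among the compounds named here.

Series notes. Compound 1 `Nc1nc(Nc2ccc(S(=O)(=O)NC(=O)CCC(=O)O)cc2)nn1C(=O)c1c(F)cccc1F` gives 23200 ng.h/mL in an ADME assay on the whole organism (plasma) for pharmacokinetics, with Rattus norvegicus as the target, at a dose of 3 mg/kg by the intravenous route; on this read-out higher numbers stand for higher exposure at the dose given and lower numbers for lower exposure. For the measured compounds named here, compound 2 `NCC(=O)NS(=O)(=O)c1ccc(Nc2nc(N)n(C(=O)c3c(F)cccc3F)n2)cc1` gives 5330 ng.h/mL in this assay, the lowest of the two numbers measured so far. Going by the values given here, the only measured step between compounds that differ in one place, a 4.4-fold lower number from compound 1 to compound 2 (0.64 log units; beyond the scatter), was made at the same saturated chain carbon bound to a carbonyl carbon. Compound 3 `COCCOCC(=O)NS(=O)(=O)c1ccc(Nc2nc(N)n(C(=O)c3c(F)cccc3F)n2)cc1` differs from compound 2 by 2-methoxyethoxy in place of amino on a saturated chain carbon bound to a carbonyl carbon. That single step shows a change at this position can move the read-out beyond the scatter, but it exchanged carboxymethyl for amino rather than amino for 2-methoxyethoxy, so it gives no direction for the present change. The expectation for compound 3 in this assay is therefore a step of a 1.5-fold higher number from compound 2 to compound 3 (0.18 log units; within the scatter), a modest rise kept close to the scatter. Compound 3 is estimated at 8000 ng.h/mL, with a range from 2500 ng.h/mL to 25000 ng.h/mL.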

Compound 3, area under the concentration-time curve: 21900 ng.h/mL
Estimate against measurement, compound 3: 2.7-fold (0.44 log units) below; measured number inside the range.
By their numbers in this assay, from the lowest: compound 2; then compounds 3 and 1 (each within the scatter of the next).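

In this assay, a second step beyond the scatter now stands at this saturated chain carbon bound to a carbonyl carbon (a 4.1-fold higher number from compound 2 to compound 3 (0.61 log units; beyond the scatter)), and it shows that 2-methoxyethoxy in place of amino goes with a higher number. The other new step (a 1.1-fold lower number from compound 1 to compound 3 (0.03 log units; within the scatter)) lies within the scatter, so a high number at this position is not tied to carboxymethyl, and of the three groups only amino, in compound 2, stands apart. What lies behind this difference remains without support from any measurement.

Open, from the compounds shown here alone, is whether a shorter methoxy group or a longer polyether chain keeps the number at this level, and whether dimethylamino falls with amino or with the other two groups. Exposure alone also leaves clearance and volume of distribution unresolved.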